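This account rests on a few compounds, and the source may have more. Where it says the series, first, only, none or still open, it means among the compounds named here.

Three related compounds have been read in a functional assay on A549 cells (Homo sapiens) for inhibition, read by MTT assay, with a stated time of 72 h; on this read-out higher numbers stand for weaker inhibition and lower numbers for stronger inhibition. Compound 1 `O=[N+]([O-])c1ccc(-c2nnc(SCCCN3CCN(c4nc5ccccc5o4)CC3)o2)cc1` gives 90800 nM, compound 2 `Fc1ccc(-c2nnc(SCCCN3CCN(c4nc5ccccc5o4)CC3)o2)cc1` gives 75700 nM, and compound 3 `O=[N+]([O-])c1ccc(-c2nnc(SCCCN3CCN(c4nc5ccccc5s4)CC3)o2)cc1` gives 96600 nM. Compound 3 therefore stands within the scatter of both others, and the three cannot be ranked.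

Compound 4 `Brc1ccc(-c2nnc(SCCCN3CCN(c4nc5ccccc5s4)CC3)o2)cc1` differs from compound 3 in one place: bromo in place of nitro on an aromatic carbon. In short, this is bromo in place of nitro on an aromatic carbon. The closest guide is the swap of nitro for fluoro, which gave a 1.2-fold lower number from compound 1 to compound 2 (0.08 log units; within the scatter). The swap of 1,3-benzoxazol-2-yl for 1,3-benzothiazol-2-yl gave a 1.1-fold higher number from compound 1 to compound 3 (0.03 log units; within the scatter), so changing that group has shown no measurable effect on the value. Among the compounds with values here, both steps are small, but no compound with bromo has been measured yet, so this guide is only indirect.

In this assay, no step beyond the scatter is therefore expected, with at most a slight drift towards a lower number, as with fluoro. The estimated step is a 1.2-fold lower number from compound 3 to compound 4 (0.08 log units; within the scatter). For compound 4, the expected value is 80000 nM, within an estimated range of 40000 nM to 130000 nM.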

Compound 4, half-maximal inhibitory concentration: 62500 nM
For compound 4 the middle estimate is 1.3-fold (0.11 log units) above the measured one, within the range that was stated.
By their numbers in this assay, from the lowest: compounds 4, 2, 1 and 3 (each within the scatter of the next).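

In this assay, going from 4-nitrophenyl to 4-bromophenyl gives a 1.5-fold lower number from compound 3 to compound 4 (0.19 log units; within the scatter). This change replaces a group of three heavy atoms with two hydrogen-bond acceptors by a single bromine atom with none, yet the step stays within the scatter, as does a 1.2-fold lower number from compound 1 to compound 2 (0.08 log units; within the scatter), the fluoro replacement made with the 1,3-benzoxazol-2-yl group in place. No measurement at hand bears on why this position tolerates the change.

The compounds shown leave open whether any group at this position can move the value beyond the scatter, such as an amine or a carboxylic acid on the aromatic ring. They also leave open whether a longer chain in place of the one joining the two halves of the shared core would do so.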